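Bile salt export pump inhibition: from compound 3 to compound 4

The source may report more compounds than this note shows. Statements on the series, on what has been measured and on what is new or still open speak of the compounds shown alone.

Compound 1, `Cc1cc(CCC(=O)O)cc(C)c1-c1nc2ccc(-c3nnc(Nc4cccc(Cl)c4)o3)cc2[nH]1`: in an ADME assay for inhibition of Bile salt export pump (Homo sapiens), read by scintillation counting, with a stated time of 5 min (a lower number here means a stronger inhibitor, a higher number a weaker inhibitor), compound 1 gives < 10000 nM, which is a limit of the assay.
Compound 2, `O=C(NO)C(CCc1ccccc1)CS(=O)(=O)N1CCN(c2ccc(F)cc2)CC1`: in this assay compound 2 gives < 10000 nM, also a limit.
Compound 3, `O=CN(O)C(CCc1cccnc1)CS(=O)(=O)N1CCC(Oc2ccc(Cl)cn2)CC1`: in this assay compound 3 gives < 10000 nM, again a limit.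

Compound 3 therefore stands only at a limit, with no number of its own; the same holds for the two other values, as the limit of < 10000 nM in this assay, at which 3 of the 3 values shown sit, states. Among the compounds with values here, no step between measured compounds is available. Compound 4, `O=CN(O)C(CCCc1ncccn1)CS(=O)(=O)N1CCC(Oc2ccc(Cl)cn2)CC1`, differs from compound 3 by (pyrimidin-2-yl)methyl in place of pyridin-3-yl on a saturated chain carbon, three bonds along the chain from an amide-type nitrogen. With nothing measured to rest on, no step beyond the usual scatter is expected, and a step that the limit leaves unreadable from compound 3 to compound 4 is expected to be small. Compound 4 is estimated at 5000 nM, within 1000 nM to 10000 nM, and will most likely again be reported only as a limit.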

Compound 4, half-maximal inhibitory concentration: < 10000 nM
Compound 4: only a limit was reported (the forecaster's own chance of this, stated with the estimate: 80%); the middle value is on the limit's open side.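

Compound 3 and compound 4 both stand only at a limit, so no step can be read between them: the limit of < 10000 nM in this assay, at which 4 of the 4 values shown sit.

The compounds shown leave open where any of them has an actual value in this assay, and whether (pyrimidin-2-yl)methyl in place of pyridin-3-yl shifts it.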